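The source may hold more compounds than are shown below. What is called first, only, known or untested is meant among the compounds shown, and "the series" means these compounds.

Of the compounds shown here, two have been measured in a functional assay on LS174T cells (Homo sapiens) for inhibition, with a stated time of 4 days; a higher number here means a weaker inhibitor, a lower number a stronger inhibitor. Compound 1 `CN(C)c1ccc(C#Cc2c(F)cccc2F)cc1` gives 25.1 nM. Compound 2 `CN(C)c1ncc(C#Cc2c(F)cccc2F)c2ccccc12` shares most of its structure with compound 1 but carries a larger core; in this assay compound 2 gives 11.8 nM. Among the compounds with values here, of these two numbers, compound 2 stands at the lower one, which in this assay is the stronger end; compound 1 is its only comparison, and the gap between them lies beyond the usual scatter of repeated measurements.

Compound 3 `CNc1ncc(C#Cc2c(F)cccc2F)c2ccccc12` has not yet been measured. It differs from compound 2 in one place: hydrogen in place of methyl on a nitrogen on an aromatic ring, which is hydrogen in place of methyl on a nitrogen on an aromatic ring, so that dimethylamino becomes methylamino.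

Within the data shown here, no measured pair in this set shows what this change does, so the expectation rests on compound 2 alone and on the smallness of the change. Compound 3 is expected to give roughly 20 nM in this assay, with a range from 7 nM to 60 nM. The expected step of a 1.7-fold higher number from compound 2 to compound 3 (0.23 log units; within the scatter) is small, a slight weakening at most, close to the scatter.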

Compound 3, half-maximal inhibitory concentration: 4.2 nM
Beside the measured number, compound 3's estimate is 4.8-fold (0.68 log units) above it; measured number below the stated range.
By their numbers in this assay, from the lowest: compound 3; then compound 2; then compound 1.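

Taking one methyl off the dimethylamino group of compound 2, which leaves methylamino, gives a stronger inhibitor in this assay, with a step of a 2.8-fold lower number from compound 2 to compound 3 (0.45 log units; beyond the scatter). Within the data shown here, this is the first view of the nitrogen on the aromatic ring as a place that responds to change: replacing a single carbon group with hydrogen shifts the number by more than repeated measurements would, and the smaller group gives the lower number. Nothing available here accounts for this step, so why the number falls cannot be said.

Among these compounds, the pair shows only one change in one direction, so it remains open whether a plain amino group, with hydrogen in place of the remaining methyl, would continue the same trend, or how a longer chain such as ethyl on this nitrogen would compare. It is also open whether the step from dimethylamino to methylamino would look the same on the smaller core of compound 1, where only the dimethylamino form is shown.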